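Methoxy for methyl on a fused indoline-type core

The source may report more compounds than this note shows. Statements on the series, on what has been measured and on what is new or still open speak of the compounds shown alone.

Measured compounds:
Compound 1, `COC(=O)[C@@]1(C)CCC=C2[C@@H]1CC[C@@H](C)[C@]2(C)Cc1c(C)[nH]c2c(C)cccc12`: 14000 nM
Compound 2, `COC(=O)[C@@]1(C)CC[C@@H]2C3=C1CC[C@@H](C)[C@]3(C)C[C@@H]1c3cc(C)ccc3N[C@H]21`: 27000 nM

Of the compounds shown here, two have been measured in a functional assay on A549 cells (Homo sapiens) for inhibition, read by sulforhodamine B assay, with a stated time of 48 h; a lower number here means a stronger inhibitor of growth, a higher number a weaker inhibitor of growth. Compound 1 gives 14000 nM in this assay. Compound 2 gives 27000 nM in this assay. Within the data shown here, the two numbers lie within the usual scatter of each other, so the two compounds cannot be separated on this evidence; both are weak inhibitors of growth on these cells, and no step between them is counted.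

Compound 3, `COC(=O)[C@@]1(C)CC[C@@H]2C3=C1CC[C@@H](C)[C@]3(C)C[C@@H]1c3cc(OC)ccc3N[C@H]21`, has not been measured. It differs from compound 2 in one place: methoxy in place of methyl on an aromatic carbon. Among the measured compounds shown here, nothing among the measured compounds tells how this assay responds to such a change, since no pair of measured compounds differs in this way.

Without a guiding step, the expectation for compound 3 rests on compound 2 alone, and the step of a 1.1-fold lower number from compound 2 to compound 3 (0.03 log units; within the scatter) is estimated to stay within the scatter, in no particular direction. Compound 3 is therefore expected to give about 25000 nM in this assay, estimated to lie between 9000 nM and 70000 nM.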

Compound 3, concentration for 50% growth inhibition: 22000 nM
Compound 3: middle estimate off by 1.1-fold (0.06 log units), on the high side; the measured number falls inside the stated range.
By their numbers in this assay, from the lowest: compounds 1, 3 and 2 (each within the scatter of the next).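

Among these compounds, the step of a 1.2-fold lower number from compound 2 to compound 3 (0.09 log units; within the scatter) in this assay is the first direct comparison at this aromatic carbon, meta to a fused ring and para to a fused ring. It shows that methoxy in place of methyl, a swap that brings in an oxygen and a hydrogen-bond acceptor, leaves the two compounds indistinguishable, so on the shared core this position carries either group with no readable difference in growth inhibition on these cells. Nothing measured here bears on the reason for this result.

Going by these compounds, whether this aromatic carbon responds at all to a group of a different kind stays open, since an amine, a carboxylic acid, a chlorine atom, plain hydrogen or a longer chain such as butoxy could each give a different reading from the two groups compared so far. Also open, on these data alone, is whether methoxy in place of methyl would read the same way on the core of compound 1, which differs from compound 2 in more than one place and so offers no comparison of its own.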